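A Trifluoromethyl Swap on a Weakly Cytotoxic Scaffold

The compounds below may be only part of what the source reports. "The series", "measured", "known", "first", "only" and "open" are said of these compounds alone.

Compound 1, `COc1ccccc1/C=c1/[nH]c(=O)/c(=C\c2ccccc2OC)[nH]c1=O`: in a functional assay on HeLa cells (Homo sapiens) for cytotoxicity, read by CCK-8 assay, with a stated time of 72 h (a higher number here means a weaker inhibitor, a lower number a stronger inhibitor), compound 1 gives "not active" (no number reported).
Compound 2, `C=CCn1c(=O)/c(=C\c2cccc(F)c2)[nH]c(=O)/c1=C\c1ccccc1OC`: in this assay compound 2 gives 9100 nM.
Compound 3, `C=CCn1c(=O)/c(=C\c2cccc(Br)c2)[nH]c(=O)/c1=C\c1cccc(Br)c1`: in this assay compound 3 gives "not active" (no number reported).

Among these three compounds, compound 2 is the only one for which a number is reported; for compound 1 and compound 3 no single number is given. Compound 2 therefore stands alone as the reference point, and its number marks it as a weak inhibitor in this assay.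

Compound 4, `C=CCn1c(=O)/c(=C\c2ccccc2C(F)(F)F)[nH]c(=O)/c1=C\c1ccccc1OC`, has not yet been measured in this assay. It differs from compound 2 in one place: 2-(trifluoromethyl)phenyl in place of 3-fluorophenyl on a double-bonded chain carbon bound to an aromatic carbon. Among the measured compounds shown here, no step between measured compounds that differ in one place is available, so the size of this change cannot be read from any neighbouring pair. Given only that compound 2 gives 9100 nM while the two other compounds returned no number, the step from compound 2 to compound 4 is expected to be small, not beyond the usual scatter, with a real chance that compound 4 also returns no number. Compound 4 is expected to give about 12000 nM, within 4000 nM to 40000 nM, an expected step of a 1.3-fold higher number from compound 2 to compound 4 (0.12 log units; within the scatter).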

Compound 4, half-maximal inhibitory concentration: 4600 nM
Beside the measured number, compound 4's estimate is 2.6-fold (0.42 log units) above it; the range from low to high includes it.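

In this assay, placing 2-(trifluoromethyl)phenyl where compound 2 carries 3-fluorophenyl, on a double-bonded chain carbon bound to an aromatic carbon, gives a 2.0-fold lower number from compound 2 to compound 4 (0.30 log units; within the scatter). This first step between measured compounds shows that this position can take a group of 10 heavy atoms in place of one of 7 and still return a number, with the two readings indistinguishable in this assay. Nothing shown bears on why the reading holds through this exchange of fluorine for trifluoromethyl.

The step alters both the substituent and its place on the phenyl ring, and the compounds shown do not separate these two parts of the change, so it remains open whether either alone would leave the number as it stands. Also open, as far as these compounds go, is whether a quite different group on this phenyl ring, such as an amine or a carboxylic acid, would carry the number beyond the scatter in either direction, or whether the whole series stays in this weak range.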